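The compounds below may be only part of what the source reports. "The series", "measured", "known", "first", "only" and "open" are said of these compounds alone.

Of the compounds shown here, three sharing a common core have been tested in a functional assay on Lu1 cells (Homo sapiens) for cytotoxicity, read by sulforhodamine B assay; on this read-out higher numbers stand for an effect only at larger amounts of compound and lower numbers for an effect already at smaller amounts. Compound 1 `C=C1CC[C@@H]2[C@](C)(CO)[C@H](OC(C)=O)CC[C@@]2(C)[C@@H]1C/C=C1/C(=O)OC[C@H]1O` gives 30.6 uM in this assay. Compound 2 `C=C1CC[C@@H]2[C@](C)(CO)[C@H](OC(C)=O)CC[C@@]2(C)[C@@H]1C/C=C1/C(=O)OC[C@H]1OC(C)=O` gives 8.75 uM in this assay. Compound 3 `C=C1CC[C@@H]2[C@](C)(CO[Si](C)(C)C(C)(C)C)[C@H](O)CC[C@@]2(C)[C@@H]1C/C=C1/C(=O)OC[C@H]1OC(C)=O` gives 10.4 uM in this assay.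

Compound 2 and compound 1 differ in only one place: hydrogen in place of acetyl on an oxygen on a saturated carbon. That change produced a step of a 3.5-fold higher number from compound 2 to compound 1 (0.54 log units; beyond the scatter), so the acetoxy form was the one that acted at smaller amounts, and the hydroxy form needed more.

Compound 3 and compound 2 differ in more than one place; the difference between the two cores is not broken down here. Compound 3 sits close to compound 2 in this assay, and the gap between them lies within the usual scatter, so nothing can be said about their order.

Compound 4 `C=C1CC[C@@H]2[C@](C)(CO[Si](C)(C)C(C)(C)C)[C@H](O)CC[C@@]2(C)[C@@H]1C/C=C1/C(=O)OC[C@H]1O` has not yet been measured. It differs from compound 3 by hydrogen in place of acetyl on an oxygen on a saturated carbon. Within the data shown here, this is the same change as the one from compound 2 to compound 1, and the place where it happens is described in the same words for both pairs. Because the earlier pair gave a 3.5-fold higher number from compound 2 to compound 1 (0.54 log units; beyond the scatter), a step of about the same size is expected from compound 3 to compound 4, namely a 3.4-fold higher number from compound 3 to compound 4 (0.53 log units; beyond the scatter). On that basis compound 4 is estimated to give 35 uM in this assay, most likely falling between 15 uM and 80 uM.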

Compound 4, concentration for half-maximal effect: 48.8 uM
Estimate against measurement, compound 4: 1.4-fold (0.14 log units) below, within the range that was stated.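

Replacing the acetyl with hydrogen, which turns the acetoxy group into a hydroxy group, had the same kind of effect on the second core as on the first: in this assay it gave a 4.7-fold higher number from compound 3 to compound 4 (0.67 log units; beyond the scatter), so the hydroxy form again needed larger amounts of compound to show an effect. Set side by side, the two steps agree in direction and, as far as the scatter allows, in size: the same change on two cores in this assay, a 3.5-fold higher number (0.54 log units; beyond the scatter) from compound 2 to compound 1 and a 4.7-fold higher number (0.67 log units; beyond the scatter) from compound 3 to compound 4, 1.3-fold (0.13 log units) apart, within the scatter of two such steps

This means that, in this small set, the effect of the change carried over from one core to the other, and the earlier step was a fair guide to the new one, but two pairs are a narrow base and show nothing about how the change would behave on any further core, or why the acetoxy form acts at smaller amounts.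

The compounds shown leave open whether the acetyl group itself matters or whether another group on the same oxygen, such as a longer chain like butanoyl, a benzoyl group or a simple methyl ether, would serve equally well. They also leave open whether an amine in place of that oxygen would give a number closer to the acetoxy or the hydroxy forms.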